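The source may report more compounds than this note shows. Statements on the series, on what has been measured and on what is new or still open speak of the compounds shown alone.

Measured compounds and their values in an ADME assay on HG23 cells (Homo sapiens) for cytotoxicity, with a stated time of 72 h; a higher number here means that more compound is tolerated, a lower number that less compound is tolerated:

compound 1 `CC(C)C[C@@H]1NC(=O)[C@@H](NC(=O)OCc2ccccc2)Cc2cn(nn2)CCNC(=O)CC[C@@H](C=O)NC1=O` — > 100000 nM
compound 2 `CC(C)C[C@@H]1NC(=O)[C@@H](NC(=O)OCc2ccccc2)Cc2cn(nn2)CCCCCCNC(=O)CC[C@@H](C=O)NC1=O` — > 100000 nM
compound 3 `O=C[C@@H]1CCC(=O)NCCCCCCn2cc(nn2)C[C@H](NC(=O)OCc2ccccc2)C(=O)N[C@@H](CC2CCCCC2)C(=O)N1` — > 100000 nM

Each of these three values is a limit of this assay, not a number. Compound 3 therefore stands only at a limit, and the two further values shown are limits as well, so no compound in the series is separated from another on the numbers shown. This is summed up in the limit of > 100000 nM in this assay, at which 3 of the 3 values shown sit.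

The step from compound 2 to compound 3 reads a step that the two limits leave unreadable from compound 2 to compound 3; its size cannot be read, as both ends sit at the limit.

Compound 4 `O=C[C@@H]1CCC(=O)NCCCCCCn2cc(nn2)C[C@H](NC(=O)OCc2ccccc2)C(=O)N[C@@H](Cc2ccccc2)C(=O)N1` differs from compound 3 by phenyl in place of cyclohexyl on a saturated chain carbon bound to a saturated ring carbon. For the measured compounds named here, the only measured step that touches the same position is the one from compound 2 to compound 3, and it is unreadable. With every value in the series at the limit, nothing points to a readable step in this assay from a change of this kind at this place; the expected step of a number no higher from compound 3 to compound 4 (the limit leaves the size open) is none beyond the scatter. Compound 4 is therefore expected to give about 100000 nM in this assay, in the range 50000 nM to 300000 nM, most likely again reported as a limit.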

Compound 4, half-maximal cytotoxic concentration: > 100000 nM
Compound 4 was reported as a limit (the forecaster's own chance of this, stated with the estimate: 85%); the middle value lies on the limit itself.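

In this assay, for the compounds shown here, the steps from compound 2 and from compound 3 to compound 4 cannot be read, so no new step follows: the limit of > 100000 nM in this assay, at which 4 of the 4 values shown sit.

The compounds shown leave open whether the isopropyl, cyclohexyl or phenyl group makes any difference to the half-maximal cytotoxic concentration.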